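The source may report more compounds than this note shows. Statements on the series, on what has been measured and on what is new or still open speak of the compounds shown alone.

Compound 1 `CNCCCNCCCNC` gives 4800 nM
Compound 2 `CNCCCCNCCCNC` gives 1700 nM
Compound 3 `CNCCCCNCCCCNC` is not yet measured

In a functional assay on L1210 cells (Mus musculus) for inhibition, with a stated time of 96 h (a higher number here means a weaker inhibitor, a lower number a stronger inhibitor), compound 2 gives 1700 nM and holds the lower of the two numbers, making it the stronger inhibitor so far. Moving on to compound 3 brings (methylamino)methyl in place of methylamino on a saturated chain carbon, three bonds along the chain from an amine nitrogen on a saturated chain carbon, three bonds along the chain from an amine nitrogen. For the measured compounds named here, the only measured step with this same exchange is a 2.8-fold lower number from compound 1 to compound 2 (0.45 log units; beyond the scatter) and a single step is thin evidence. A similar or somewhat smaller drop is therefore expected, and the estimate is a 1.9-fold lower number from compound 2 to compound 3 (0.28 log units; within the scatter) in this assay again. Compound 3 is estimated at 900 nM with an expected range of 350 nM to 2300 nM for the measurement.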

Compound 3, half-maximal inhibitory concentration: 900 nM
Beside the measured number, compound 3's estimate shows no gap at the digits printed; the measured number falls inside the stated range.
By their numbers in this assay, from the lowest: compounds 3 and 2 (each within the scatter of the next); then compound 1.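

Putting (methylamino)methyl in place of methylamino a second time gives a 1.9-fold lower number from compound 2 to compound 3 (0.28 log units; within the scatter) in this assay and so no longer separates the two compounds, unlike the earlier step, a 2.8-fold lower number from compound 1 to compound 2 (0.45 log units; beyond the scatter) and clearly measurable. The gain seen the first time is therefore not shown to repeat at this position. No measurement available here explains why the two steps read differently.

Still open, going by these compounds, is whether a longer chain, such as 2-(methylamino)ethyl in place of (methylamino)methyl, would keep, improve or lose this level of inhibition. How an amide or a carboxylic acid would fare at this place is also unknown.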